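Removing the Large Oxygen Substituent from Compound 2

The source may hold more compounds than are shown below. What is called first, only, known or untested is meant among the compounds shown, and "the series" means these compounds.

In a functional assay on PANC-1 cells (Homo sapiens) for cytotoxicity, read by MTT assay, with a stated time of 48 h, in the presence of a further agent that is not named here (on this read-out higher numbers stand for weaker inhibition and lower numbers for stronger inhibition), compound 1 `CC1(C)OB(c2ccc(COc3cccc4ccc(C(=O)N5CCC(Oc6no[n+]([O-])c6S(=O)(=O)c6ccccc6)CC5)nc34)cc2)OC1(C)C` gives 38300 nM, while compound 2 `O=C(NCCCOc1no[n+]([O-])c1S(=O)(=O)c1ccccc1)c1ccc2cccc(OCc3ccc(B(O)O)cc3)c2n1` gives 17600 nM. Compound 2 therefore holds the lower number of the two, and the gap between them lies beyond the usual scatter. These two compounds differ in more than one place, so they isolate no single change. Compound 3 `O=C(NCCCOc1no[n+]([O-])c1S(=O)(=O)c1ccccc1)c1ccc2cccc(O)c2n1` comes from compound 2 by one change: a hydrogen atom in place of a group of 10 heavy atoms (7 carbon, 1 boron, 2 oxygen; one six-membered aromatic ring of carbon only), on an oxygen on an aromatic ring. It places a hydrogen atom on an oxygen on an aromatic ring. Going by the values given here, no measured step shows the size of this change in this assay, so the expectation is loose: a moderate move towards stronger inhibition, with no change beyond the scatter still possible. The estimated step is a 2.0-fold lower number from compound 2 to compound 3 (0.29 log units; within the scatter). For compound 3 the estimated value is 9000 nM, with an expected range from 2500 nM to 35000 nM.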

Compound 3, half-maximal inhibitory concentration: 13900 nM
The estimate for compound 3 lay 1.5-fold (0.19 log units) below the measured number; low and high end bracket the measured number.
By their numbers in this assay, from the lowest: compounds 3 and 2 (each within the scatter of the next); then compound 1.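

In this assay, a hydrogen atom can take the place of the group of 10 heavy atoms, with its boron and its six-membered aromatic ring of carbon only, on an oxygen on an aromatic ring, giving a 1.3-fold lower number from compound 2 to compound 3 (0.10 log units; within the scatter). This is the only step shown between compounds that differ in one place, and it indicates that, at this position, the whole group can go without the number leaving the scatter. No measurement available here offers an explanation for this result.

On these data alone, whether a smaller group on this oxygen, such as a methyl group, or a plain benzyl group without boron would give a different number remains open. So does the effect of an amine in place of this oxygen, or of a longer chain on the amide of compound 3.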